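Fluoro for chloro in a small amide series

The compounds below may be only part of what the source reports. "The series", "measured", "known", "first", "only" and "open" are said of these compounds alone.

Measured so far in a functional assay on the whole organism (strain Swiss) with Mus musculus as the target, in the maximal electroshock model, with a stated time of 1 h, at a dose of 300 mg/kg by the intraperitoneal route; a higher number here means a stronger effect of the compound at the dose given, a lower number a weaker effect:
compound 1, `COc1cccc(N2CCN(C(=O)C(C)N3C(=O)CCC3=O)CC2)c1`, gives 0%;
compound 2, `CCC(C(=O)N1CCN(c2ccc(Cl)cc2)CC1)N1C(=O)CCC1=O`, gives 25%;
compound 3, `CC(C(=O)N1CCN(c2ccc(Cl)cc2)CC1)N1C(=O)CCC1=O`, gives 0%.

Compound 2 stands highest of the three numbers; the nearest and the furthest value, compound 1 and compound 3, both sit the same distance below it, beyond the scatter. Two single-change steps are known. One, no change at the digits printed from compound 1 to compound 3 (within the scatter), joins two compounds with no measurable effect, so it says nothing about whether an aryl change matters once activity is present. The other, a number 25 percentage points lower from compound 2 to compound 3 (beyond the scatter), concerns hydrogen in place of methyl on a saturated chain carbon, not the aromatic ring.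

Compound 4, `CCC(C(=O)N1CCN(c2ccc(F)cc2)CC1)N1C(=O)CCC1=O`, differs from compound 2 by fluoro in place of chloro on an aromatic carbon. For the measured compounds named here, no measured step touches this change directly. With the aryl swap in the series having shown no movement, and the methyl of compound 2 kept, compound 4 is expected to stay near compound 2, the step being a number 3 percentage points lower from compound 2 to compound 4 (within the scatter), nothing beyond the scatter. The estimate for compound 4 in this assay is 22%, within 0% to 45%.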

Compound 4, a percentage reported as activity, at one dose (the size of the read-out at that dose, not a potency): 25%
For compound 4 the middle estimate is 3 percentage points below the measured one, and the stated range covers the measured number.
By their numbers in this assay, from the lowest: compounds 1 and 3 (each within the scatter of the next); then compounds 2 and 4 (each within the scatter of the next).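

In this assay, fluoro in place of chloro on an aromatic carbon, para to a large group, gives no change at the digits printed from compound 2 to compound 4 (within the scatter). Unlike the earlier aryl step, which joined two compounds without a measurable effect, this one is read between two compounds that both show an effect, so 4-chlorophenyl to 4-fluorophenyl leaves the read-out intact at this single dose while the methyl on the saturated chain carbon is kept. No measurement at hand accounts for this flat step.

Still open, as far as these compounds go, is whether a heavier departure at the same ring position, such as a nitrile or a carboxylic acid, would keep the effect. Also open, from the compounds shown here alone, is how a longer chain in place of that methyl would read in this assay.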